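Swapping the Group on the Carbonyl of Compound 3

The source may hold more compounds than are shown below. What is called first, only, known or untested is meant among the compounds shown, and "the series" means these compounds.

In an ADME assay on Caco-2 cells (Homo sapiens) for permeability, in the apical to basolateral direction, at pH 7.4 (on this read-out lower numbers stand for lower permeability and higher numbers for higher permeability), three compounds with a shared core differ only in the group on a carbonyl carbon. Compound 1 (`Cc1csc(C(=O)N[C@H]2CN(S(=O)(=O)c3ccccc3)C[C@@H]2C(=O)N[C@H]2CCCNC2)n1`) reads 0.18 10^-6 cm/s and compound 2 (`O=C(N[C@H]1CN(S(=O)(=O)c2ccccc2)C[C@@H]1C(=O)N[C@H]1CCCNC1)c1cn(C2CC2)cn1`) reads 0.48 10^-6 cm/s on this scale. Compound 3 (`O=C(N[C@H]1CN(S(=O)(=O)c2ccccc2)C[C@@H]1C(=O)N[C@H]1CCCNC1)c1cc(-c2ccccc2)on1`) reads 0.12 10^-6 cm/s and so sits level with compound 1 within the scatter, while compound 2 stands clearly apart (a 4.0-fold lower number from compound 2 to compound 3 (0.60 log units; beyond the scatter)).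

Compound 4 (`O=C(N[C@H]1CN(S(=O)(=O)c2ccccc2)C[C@@H]1C(=O)N[C@H]1CCCNC1)c1nnc(-c2ccc(F)cc2)s1`) is still unmeasured and differs from compound 3 in one place (a group of 12 heavy atoms (8 carbon, 2 nitrogen, 1 fluorine, 1 sulfur; one five-membered aromatic ring with 3 hetero atoms, one six-membered aromatic ring of carbon only) in place of a group of 11 heavy atoms (9 carbon, 1 nitrogen, 1 oxygen; one five-membered aromatic ring with 2 hetero atoms, one six-membered aromatic ring of carbon only), on a carbonyl carbon). Both groups hold one five-membered aromatic ring and one six-membered aromatic ring of carbon only. The measured swaps at this place range from a step within the scatter (a 1.5-fold lower number from compound 1 to compound 3 (0.18 log units; within the scatter)) to modest ones (a 2.7-fold higher number from compound 1 to compound 2 (0.43 log units; beyond the scatter)). None of them exchanges two groups that both hold such a six-membered ring, so the evidence is indirect. No step beyond the scatter is therefore expected in this assay, and the expected step (no change at the digits printed from compound 3 to compound 4 (within the scatter)) has no firm direction. For compound 4 the estimated value is 0.12 10^-6 cm/s (range 0.05 10^-6 cm/s to 0.3 10^-6 cm/s).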

Compound 4, apparent permeability: < 0.03 10^-6 cm/s
Compound 4: no number, only a limit; the forecaster's own chance of this, stated with the estimate: 10%; at least 4.0-fold (0.60 log units) between middle value and limit.
By their numbers in this assay, from the lowest: compounds 3 and 1 (each within the scatter of the next); then compound 2. At a limit, below all of these: compound 4.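

Compound 4 gives no number in this assay, only a limit of the assay: the limit of < 0.03 10^-6 cm/s in this assay, at which 1 of the 4 values shown sits.

Among the compounds shown here, this is the first exchange at the carbonyl carbon in which both groups hold a six-membered aromatic ring of carbon only, and it still gives an at least 4.0-fold lower number from compound 3 to compound 4 (0.60 log units; beyond the scatter), so sharing those ring types does not keep the read-out level. The new group also lies well away from the two groups without that six-membered ring, with an at least 16-fold lower number from compound 2 to compound 4 (1.20 log units; beyond the scatter) and an at least 6.0-fold lower number from compound 1 to compound 4 (0.77 log units; beyond the scatter).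

The limit leaves the true size of these steps open. On these data alone, the five-membered ring and the fluorine change together, so it also remains open how the read-out would respond to the same five-membered ring carrying a plain phenyl, or to an amine in place of the fluorine.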